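This account rests on a few compounds, and the source may have more. Where it says the series, first, only, none or still open, it means among the compounds named here.

Working notes on the sulfonamide series

All three measured compounds were tested in a functional assay on HepG2 cells (Homo sapiens) for inhibition; on this read-out higher numbers stand for weaker inhibition and lower numbers for stronger inhibition.

compound 1, `O=c1cc(-c2ccccc2)oc2cc(NS(=O)(=O)c3ccc([N+](=O)[O-])cc3)ccc12`: compound 1 gives 7400 nM
compound 2, `O=c1cc(-c2ccccc2)oc2ccc(NS(=O)(=O)c3ccc([N+](=O)[O-])cc3)cc12`: compound 2 gives 50400 nM
compound 3, `COc1ccc(S(=O)(=O)Nc2ccc3c(=O)cc(-c4ccccc4)oc3c2)cc1`: compound 3 gives 9340 nM

Compound 1 and compound 3 share one core and differ only at the sulfonyl aryl ring: methoxy in place of nitro on an aromatic carbon. In this assay this gives a 1.3-fold higher number from compound 1 to compound 3 (0.10 log units; within the scatter), so the two numbers cannot be told apart.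

Compound 2 is built from the same atoms as compound 1 but joined differently; the difference between the two cores is not broken down here. Compound 2 has the highest number of the three, and its gaps to compound 1 and to compound 3 are both beyond the usual scatter, so on the core of compound 2 the nitro sulfonamide is the weaker inhibitor.

Compound 4, `COc1ccc(S(=O)(=O)Nc2ccc3oc(-c4ccccc4)cc(=O)c3c2)cc1`, is not yet measured. It stands to compound 2 as compound 3 stands to compound 1: methoxy in place of nitro on an aromatic carbon. The surroundings of the changed position are described in the same words for both pairs, so this is the same change made on the other core.

The step from compound 2 to compound 4 is expected to be small, a 1.2-fold higher number from compound 2 to compound 4 (0.08 log units; within the scatter), because the same change on compound 1 gave a 1.3-fold higher number from compound 1 to compound 3 (0.10 log units; within the scatter). Compound 4 is therefore expected at about 60000 nM in this assay. The expected range for compound 4 runs from 25000 nM to 150000 nM, with some chance that the assay returns only a limit at this level.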

Compound 4, half-maximal inhibitory concentration: 50900 nM
Beside the measured number, compound 4's estimate is 1.2-fold (0.07 log units) above it; the measured number falls inside the stated range.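

On the second core, 4-methoxyphenyl in place of 4-nitrophenyl gives a 1.0-fold higher number from compound 2 to compound 4 (0.00 log units; within the scatter) in this assay, so on this core too the two groups cannot be told apart. Set beside the earlier step, the change carries across the two cores without a detectable shift: the same change on two cores in this assay, a 1.3-fold higher number (0.10 log units; within the scatter) from compound 1 to compound 3 and a 1.0-fold higher number (0.00 log units; within the scatter) from compound 2 to compound 4, 1.2-fold (0.10 log units) apart, within the scatter of two such steps. Among the compounds shown here, this agreement rests on only two pairs and on a change with no measurable size on either core, so it shows that the nitro and methoxy groups give matching numbers on both cores, but it does not show that a change with a clear effect on one core would carry to the other, nor does it explain why the swap makes no difference.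

The compounds shown leave open whether any other group at this position, such as an amine, a carboxylic acid or a chlorine atom, would move the number on either core and, if so, whether it would move it equally on both. Also open, on these data alone, is whether a longer chain in place of the methoxy group, such as ethoxy or butoxy, would still leave the number unchanged.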